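The source may report more compounds than this note shows. Statements on the series, on what has been measured and on what is new or still open speak of the compounds shown alone.

In a functional assay on RAW264.7 cells (Mus musculus) for cytotoxicity, read by MTT assay, with a stated time of 24 h (a lower number here means a stronger inhibitor, a higher number a weaker inhibitor), compound 1 (`O=S(=O)(O)OCCCCCCCCCC[Se]c1ccccc1`) gives > 100000 nM, which is a limit and not a number. Compound 2 (`O=S(=O)(O)OCCCCCCCCCCCC[Se]c1ccccc1`) gives > 100000 nM, which is also a limit, so its place on the scale cannot be fixed any more closely. Compound 3 (`O=S(=O)(O)OCCCCCCCCCCC[Se]c1ccccc1`) has yet to be measured. It carries sulfooxy in place of (sulfooxy)methyl on a saturated chain carbon, ten or more bonds along the chain from a selenium atom. Among the compounds with values here, the only measured step on this chain is a step that the two limits leave unreadable from compound 1 to compound 2, and the evidence amounts to the limit of > 100000 nM in this assay, at which 2 of the 2 values shown sit. Within the data shown here, with that step as the sole guide, no change beyond the scatter is expected in this assay, in either direction. The expected step is a number no higher from compound 2 to compound 3 (the limit leaves the size open). Compound 3 is estimated at 100000 nM, within an expected range of 60000 nM to 200000 nM.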

Compound 3, half-maximal inhibitory concentration: > 100000 nM
Compound 3 gave a limit, no number (the forecaster's own chance of this, stated with the estimate: 90%); the middle value lies on the limit itself.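

Within the data shown here, compound 1, compound 2 and compound 3 each give only a limit in this assay, not a number, so no step among them can be read. The compounds shown leave open where any of the three lies on the scale, and whether the chain's length matters here at all.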